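A few compounds are considered here, and "the series" means these few. Any claim that something is new, unique, unknown or untested is made for them only; others in the source may bear on it.

This piece follows a single change in a series of thromboxane receptor antagonists, read in a functional assay on blood for antagonist activity at thromboxane A2 receptor (Homo sapiens); a higher number here means weaker binding, a lower number tighter binding. Compound 1 `O=C(O)CC/C=C\CO[C@H]1C(OCc2ccc(-c3ccccc3)cc2)CC[C@@H]1N1CCCCC1` was measured twice and gave 63.1 nM; 15.9 nM (2 entries), as the two entries show (the several entries of compound 1 in this assay, 63.1 nM; 15.9 nM (2 entries)); with no single number it stands aside when the others are ranked. Compound 3 `O=C(O)CC/C=C\CO[C@H]1[C@@H](OCc2ccc(-c3ccccc3CO)cc2)CC[C@@H]1N1CCCCCC1` gives 1.59 nM. Compound 2 `NC(=O)Cc1ccccc1-c1ccc(COC2CC[C@H](N3CCCCCC3)[C@H]2OC/C=C\CCC(=O)O)cc1` gives 7.94 nM, the higher of the two single numbers; its nearest neighbour is compound 3, whose number lies lower by a gap beyond the scatter. The new structure is compound 4 `O=C(O)CC/C=C\CO[C@H]1C(OCc2ccc(-c3ccccc3O)cc2)CC[C@@H]1N1CCCCCC1`. It differs from compound 2 in one place: hydroxy in place of carbamoylmethyl on an aromatic carbon. For the measured compounds named here, no pair of measured compounds shows this exact change, so the size of its effect is not known from the data. In this assay a small step toward a lower number is expected, one that may not clearly pass beyond the scatter, and the expected step is a 2.0-fold lower number from compound 2 to compound 4 (0.30 log units; within the scatter). Compound 4 is therefore estimated at 4 nM, with a range from 1 nM to 16 nM.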

Compound 4, dissociation constant: 15.9 nM
Beside the measured number, compound 4's estimate is 4.0-fold (0.60 log units) below it, within the range that was stated.
By their numbers in this assay, from the lowest: compound 3; then compounds 2 and 4 (each within the scatter of the next).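

For the compounds shown here, this pair gives the first reading of a change at this spot, on an aromatic carbon of a six-membered aromatic ring of carbon only, ortho to a large group: in this assay there is a 2.0-fold higher number from compound 2 to compound 4 (0.30 log units; within the scatter). Carbamoylmethyl, with 4 heavy atoms, can thus give way to hydroxy, with 1 heavy atom, without a shift that stands clear of the scatter, and each group carries 1 hydrogen-bond donor and 1 hydrogen-bond acceptor. Repeat readings of a single compound can differ by more than this step: the several entries of compound 1 in this assay, 63.1 nM; 15.9 nM (2 entries)

The pair alone cannot tell whether the donor and acceptor that both groups carry matter at this position. Nor do the compounds shown tell how methoxy or an amine on the same aromatic carbon would read.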